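Benzylic aryl swap in the sulfamate series: compound 4

The compounds below may be only part of what the source reports. "The series", "measured", "known", "first", "only" and "open" are said of these compounds alone.

Compound 3 `CCN(Cc1ccccn1)c1ccc(C(=O)N2CCc3ccc(OS(N)(=O)=O)cc3C2)cc1` stands second of the three measured compounds in an assay on HEK293 cells for inhibition of Steryl-sulfatase (Homo sapiens), tested at 0.1 uM (on this read-out higher numbers stand for a stronger effect at the one concentration tested and lower numbers for a weaker effect), with 42.5%. Compound 1 `CCN(Cc1cccc(Br)c1)c1ccc(C(=O)N2CCc3ccc(OS(N)(=O)=O)cc3C2)cc1` gives 80.2% and compound 2 `NS(=O)(=O)Oc1ccc2c(c1)CN(C(=O)c1ccc(N3CCCCC3)cc1)CC2` gives 11.5%. Compound 4 `CCN(Cc1ccc(F)cc1)c1ccc(C(=O)N2CCc3ccc(OS(N)(=O)=O)cc3C2)cc1` differs from compound 3 by 4-fluorophenyl in place of pyridin-2-yl on a saturated chain carbon bound to a nitrogen on an aromatic ring. The step that bears on it is a number 37.7 percentage points lower from compound 1 to compound 3 (beyond the scatter), a large drop when 3-bromophenyl at this place gave way to pyridin-2-yl; compound 4 returns a carbon-only ring to that position. The step of a number 31 percentage points higher from compound 2 to compound 3 (beyond the scatter) shows the ethyl((pyridin-2-yl)methyl)amino group well above piperidin-1-yl, so the open-chain amine itself is retained here. For compound 4 a rise beyond the scatter is expected, a number 22.5 percentage points higher from compound 3 to compound 4 (beyond the scatter), though fluorine is not bromine and the full return is uncertain. Compound 4 is estimated at 65% with a range of 45% to 85%.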

Compound 4, a percentage reported as inhibition, at one concentration (the size of the read-out at that concentration, not a potency): 69.1%
Estimate against measurement, compound 4: 4.1 percentage points below, within the range that was stated.
By their numbers in this assay, from the lowest: compound 2; then compound 3; then compound 4; then compound 1.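

At the saturated chain carbon bound to a nitrogen on an aromatic ring, 4-fluorophenyl recovers most of what pyridin-2-yl gave up (a number 26.6 percentage points higher from compound 3 to compound 4 (beyond the scatter)), and ethyl(4-fluorobenzyl)amino stands far clear of piperidin-1-yl (a number 57.6 percentage points higher from compound 2 to compound 4 (beyond the scatter)). This ring still does not fully match 3-bromophenyl (a number 11.1 percentage points lower from compound 1 to compound 4 (beyond the scatter)), so the choice of carbon-only ring also matters at this place. No measurement at hand accounts for these differences.

The compounds shown leave open whether the halogen itself or its place on the ring carries the remaining gap. An unsubstituted benzyl, 3-fluorobenzyl or 4-bromobenzyl group would separate these readings.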